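Swapping the aryl group on a urea-linked thiophene-fused core

The source may hold more compounds than are shown below. What is called first, only, known or untested is meant among the compounds shown, and "the series" means these compounds.

Measured compounds:
- compound 1 `Cc1ccc(NC(=O)Nc2nnc(Sc3ncnc4scc(-c5ccncc5)c34)s2)cc1Cl`: 23200 nM
- compound 2 `O=C(Nc1ccc(Cl)c(C(F)(F)F)c1)Nc1nnc(Sc2ncnc3scc(-c4ccncc4)c23)s1`: 18400 nM

Both compounds share one core and differ only in the aryl group carried on the urea nitrogen. In a functional assay on HUVEC cells (Homo sapiens) for antiproliferative activity, read by MTT assay, with a stated time of 48 h (a lower number here means a stronger inhibitor, a higher number a weaker inhibitor), compound 2 gives the lower of the two numbers, but the gap to compound 1 is small: a 1.3-fold lower number from compound 1 to compound 2 (0.10 log units; within the scatter). So the two values cannot be told apart.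

Compound 3 `O=C(Nc1cccc(F)c1)Nc1nnc(Sc2ncnc3scc(-c4ccncc4)c23)s1` has not yet been measured. It differs from compound 2 by 3-fluorophenyl in place of 4-chloro-3-(trifluoromethyl)phenyl on an amide-type nitrogen. Within the data shown here, the only step available that touches this position is a 1.3-fold lower number from compound 1 to compound 2 (0.10 log units; within the scatter), and it stayed within the scatter. That single step gives no basis for expecting a change in this assay beyond the scatter in either direction. For compound 3 a number close to that of compound 2 is therefore expected, a 1.4-fold higher number from compound 2 to compound 3 (0.13 log units; within the scatter), with an estimate of 25000 nM and a range from 10000 nM to 60000 nM.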

Compound 3, half-maximal inhibitory concentration: 13700 nM
For compound 3 the middle estimate is 1.8-fold (0.26 log units) above the measured one; low and high end bracket the measured number.
By their numbers in this assay, from the lowest: compounds 3, 2 and 1 (each within the scatter of the next).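

In this assay, 3-fluorophenyl on the amide-type nitrogen gives a 1.3-fold lower number from compound 2 to compound 3 (0.13 log units; within the scatter) in place of 4-chloro-3-(trifluoromethyl)phenyl and a 1.7-fold lower number from compound 1 to compound 3 (0.23 log units; within the scatter) in place of 3-chloro-4-methylphenyl. This position has now carried three different substituted phenyl groups, and even the exchange of an 11-heavy-atom group bearing chlorine and trifluoromethyl for a 7-heavy-atom group bearing only fluorine leaves the numbers within the scatter. No measurement offered here explains this result.

From the compounds shown here alone, all three groups are phenyl rings carrying halogen, so it remains open whether a plain phenyl, a phenyl bearing an amine or a carboxylic acid, or a saturated ring such as cyclohexyl would give a different number. Whether any group at this position can separate itself beyond the scatter also stays unanswered.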